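Phenyl amide removal in the thiazole-benzofuran series

This account rests on a few compounds, and the source may have more. Where it says the series, first, only, none or still open, it means among the compounds named here.

For the measured compounds named here, compound 2 `COc1cc(OCc2csc(-c3ccc(C(N)=O)cc3)n2)c2cc(-c3cn4nc(OC)sc4n3)oc2c1` stands lowest of the two numbers so far in a functional assay on HEK293 cells for antagonist activity at proteinase-activated receptor 4 (Homo sapiens), read by FLIPR and calcium flux, with a stated time of 30 min (a lower number here means a stronger inhibitor, a higher number a weaker inhibitor), where compound 2 gives 0.3 nM. Going by the values given here, its nearest neighbour, compound 1 `COc1cc(OCc2csc(-c3cccc(C(=O)N(C)C)c3)n2)c2cc(-c3cn4nc(OC)sc4n3)oc2c1`, gives 0.8 nM, and the only measured step, a 2.7-fold lower number from compound 1 to compound 2 (0.43 log units; beyond the scatter), alters the amide rather than deleting it. Compound 3 `COc1cc(OCc2csc(-c3ccccc3)n2)c2cc(-c3cn4nc(OC)sc4n3)oc2c1` carries hydrogen in place of carbamoyl on an aromatic carbon, read one bond further out as 4-carbamoylphenyl to phenyl. Among the compounds with values here, no measured step tests loss of the group outright; the single step shows the assay is sensitive to the amide. A modest weakening is expected. Compound 3 is estimated at 1.2 nM (range 0.4 nM to 4 nM), meaning an expected step of a 4.0-fold higher number from compound 2 to compound 3 (0.60 log units; beyond the scatter).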

Compound 3, half-maximal inhibitory concentration: 0.3 nM
Beside the measured number, compound 3's estimate is 4.0-fold (0.60 log units) above it, and the stated range ends above it.
By their numbers in this assay, from the lowest: compounds 2 and 3 (each within the scatter of the next); then compound 1.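

Removing the carbamoyl group gives no change at the digits printed from compound 2 to compound 3 (within the scatter) in this assay, so this amide on the phenyl ring is not needed for the activity seen here. Hydrogen in place of dimethylcarbamoyl gives a 2.7-fold lower number from compound 1 to compound 3 (0.43 log units; beyond the scatter), so the earlier step reads as a cost carried by the 3-(dimethylcarbamoyl)phenyl rather than a gain from the 4-carbamoylphenyl. Nothing available explains this result.

Still open, on these data alone, is whether a carboxylic acid or an amine on this phenyl ring would leave the number unchanged or shift it in either direction.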